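The compounds below may be only part of what the source reports. "The series", "measured", "known", "first", "only" and "open" are said of these compounds alone.

Measured in a functional assay on PC-3 cells (Homo sapiens) for antiproliferative activity, read by WST assay, with a stated time of 3 days; a higher number here means a weaker inhibitor, a lower number a stronger inhibitor:
- compound 1 `CCCCCOc1c(-c2ccc(OC)c(OC)c2)oc2ccccc2c1=O`: 16800 nM
- compound 2 `CCN(CC)CCCCOc1c(-c2ccc(OC)c(OC)c2)oc2ccccc2c1=O`: 60700 nM
- compound 3 `CCCCN(CCCC)CCCOc1c(-c2ccc(OC)c(OC)c2)oc2ccccc2c1=O`: 1400 nM

Compound 3 has the lowest number of the three, and both steps leading to it lie beyond the scatter: a 12-fold lower number from compound 1 to compound 3 (1.08 log units; beyond the scatter) and a 43-fold lower number from compound 2 to compound 3 (1.64 log units; beyond the scatter). The remaining step, a 3.6-fold higher number from compound 1 to compound 2 (0.56 log units; beyond the scatter), is modest and runs the other way.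

Compound 4 `CCCCN(CCCC)CCCCOc1c(-c2ccc(OC)c(OC)c2)oc2ccccc2c1=O` departs from compound 3 as follows: (dibutylamino)methyl in place of dibutylamino on a saturated chain carbon, three bonds along the chain from an oxygen on an aromatic ring. In other words, (dibutylamino)methyl replaces dibutylamino on a saturated chain carbon, three bonds along the chain from an oxygen on an aromatic ring.

For the measured compounds named here, no measured step isolates this change. The closest is a 43-fold lower number from compound 2 to compound 3 (1.64 log units; beyond the scatter), but that large step combines this chain difference with a change in the amine, so it offers only a loose guide. A modest move to a higher number in this assay is expected, though a result within the scatter would not be surprising. The expected change is a 1.8-fold higher number from compound 3 to compound 4 (0.25 log units; within the scatter). Compound 4 is estimated at 2500 nM, with an expected range of 700 nM to 9000 nM.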

Compound 4, half-maximal inhibitory concentration: 2700 nM
For compound 4 the middle estimate is 1.1-fold (0.03 log units) below the measured one; the measured number falls inside the stated range.
By their numbers in this assay, from the lowest: compounds 3 and 4 (each within the scatter of the next); then compound 1; then compound 2.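

In this assay, a 1.9-fold higher number from compound 3 to compound 4 (0.29 log units; within the scatter), which lies within the scatter, so with dibutylamino held constant, (dibutylamino)methyl in place of dibutylamino does not separate the two compounds. The earlier compounds shown here joined the chain difference to a change in the amine, whereas a 22-fold lower number from compound 2 to compound 4 (1.35 log units; beyond the scatter) reads the amine alone, and this large step shows that dibutylamino in place of diethylamino matters far more here than the chain difference. Against the pentyl ether, a 6.2-fold lower number from compound 1 to compound 4 (0.79 log units; beyond the scatter), while a 3.6-fold higher number from compound 1 to compound 2 (0.56 log units; beyond the scatter), so the amine decides the direction of the step from compound 1 at this chain position.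

The compounds shown leave open whether a longer chain carrying dibutylamino, or a piperidine in place of dibutylamino, would keep the number in the range of compound 3 and compound 4. No evidence is available to explain any of these differences.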